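The source may hold more compounds than are shown below. What is called first, only, known or untested is meant among the compounds shown, and "the series" means these compounds.

The series shares a thiosemicarbazone motif and is tested in a functional assay on HT-29 cells (Homo sapiens) for antiproliferative activity, read by sulforhodamine B assay, with a stated time of 72 h; on this read-out lower numbers stand for stronger inhibition and higher numbers for weaker inhibition. Compound 1 `CN(C)C(=S)N/N=C/c1cc2cccnc2s1` gives 13400 nM. Compound 3 `NC(=S)N/N=C/c1cc2cccnc2s1` reaches only the assay limit of > 100000 nM. That gives an at least 7.4-fold higher number from compound 1 to compound 3 (0.87 log units; beyond the scatter). Compound 2 `COc1ccc(C)cc1NC(=S)N/N=C/c1ccc2ccccc2n1`, built on a different core, likewise gives only the assay limit of > 100000 nM; it therefore stands at the weak end of what is shown, a position it shares with the limit of > 100000 nM in this assay, at which 2 of the 3 values shown sit.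

Compound 4 `Cc1cccc(NC(=S)N/N=C/c2ccc3ccccc3n2)c1` differs from compound 2 in one place: hydrogen in place of methoxy on an aromatic carbon. Among the compounds with values here, the only measured step, that from compound 1 to compound 3, concerns the substituent on the thiocarbonyl carbon, not the aromatic ring, so no measured step bears directly on this change. Without such evidence, the expectation for compound 4 is simply that it stays near compound 2, with a step of a number no higher from compound 2 to compound 4 (the limit leaves the size open) in this assay. Compound 4 is thus estimated at 100000 nM, with a range from 30000 nM to 300000 nM, and most likely reported again only as a limit.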

Compound 4, half-maximal inhibitory concentration: > 100000 nM
Compound 4: only a limit was reported; the forecaster's own chance of this, stated with the estimate: 70%; the middle value sits exactly at the limit.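

Compound 2 and compound 4 are both reported only as a limit, not as a number, so no step between them can be read: the limit of > 100000 nM in this assay, at which 3 of the 4 values shown sit.

The compounds shown leave open whether hydrogen in place of methoxy on an aromatic carbon changes the result in this assay at all.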